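A Sulfonamide Nitrogen Swap Repeated on a Second Core

The source may hold more compounds than are shown below. What is called first, only, known or untested is meant among the compounds shown, and "the series" means these compounds.

Compound 1 `CC(C)(C)c1cc(C(C)(C)C)c2oc(=O)c(/C=N/c3ccc(S(=O)(=O)NC(=N)N)cc3)c(Cl)c2c1` carries a sulfonamide whose nitrogen bears a small, ring-free group. In a functional assay on MCF7 cells (Homo sapiens) for cytotoxicity, read by CCK-8 assay, with a stated time of 48 h (on this read-out lower numbers stand for stronger inhibition and higher numbers for weaker inhibition), compound 1 gives 18 nM. Compound 2 `Cc1cc(C)nc(NS(=O)(=O)c2ccc(/N=C/c3c(Cl)c4cc(C(C)(C)C)cc(C(C)(C)C)c4oc3=O)cc2)n1` differs only at that nitrogen: a group of 8 heavy atoms (6 carbon, 2 nitrogen; one six-membered aromatic ring with 2 hetero atoms) in place of a group of 3 heavy atoms (1 carbon, 2 nitrogen; no ring), on a sulfonamide nitrogen. In this assay compound 2 gives 8.8 nM, so this change brought a 2.0-fold lower number from compound 1 to compound 2 (0.31 log units; beyond the scatter).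

Compound 3 `Cc1ccc2oc(=O)c(/C=N/c3ccc(S(=O)(=O)NC(=N)N)cc3)c(Cl)c2c1` keeps the small, ring-free group on the sulfonamide nitrogen but sits on a different core; how the two cores differ is not broken down here. In this assay compound 3 gives 67 nM, the highest number of the three measured compounds.

Compound 4 `Cc1ccc2oc(=O)c(/C=N/c3ccc(S(=O)(=O)Nc4nc(C)cc(C)n4)cc3)c(Cl)c2c1` applies the same change to compound 3: a group of 8 heavy atoms (6 carbon, 2 nitrogen; one six-membered aromatic ring with 2 hetero atoms) in place of a group of 3 heavy atoms (1 carbon, 2 nitrogen; no ring), on a sulfonamide nitrogen. The surroundings of the place, a sulfonamide nitrogen whose other neighbour is the sulfonyl sulfur, are the same as in the first pair, so this is the same change on another core. Because the same change gave a 2.0-fold lower number from compound 1 to compound 2 (0.31 log units; beyond the scatter), the estimated step is a 2.0-fold lower number from compound 3 to compound 4 (0.31 log units; beyond the scatter). Compound 4 is therefore expected at 33 nM, with a likely range from 15 nM to 80 nM.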

Compound 4, half-maximal inhibitory concentration: 25 nM
Compound 4: middle estimate off by 1.3-fold (0.12 log units), on the high side; low and high end bracket the measured number.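

Putting 4,6-dimethylpyrimidin-2-yl on the sulfonamide nitrogen of the core of compound 3 gave a 2.7-fold lower number from compound 3 to compound 4 (0.43 log units; beyond the scatter) in this assay. The change therefore carried over from one core to the other in the same direction and with a similar size: the same change on two cores in this assay, a 2.0-fold lower number (0.31 log units; beyond the scatter) from compound 1 to compound 2 and a 2.7-fold lower number (0.43 log units; beyond the scatter) from compound 3 to compound 4, 1.3-fold (0.12 log units) apart, within the scatter of two such steps. Going by these compounds alone, with only two pairs, this shows that the step held on these two cores, but not that it would hold on any other core, and the numbers alone do not explain why the change lowers the read-out.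

The compounds shown leave open whether a similar step would appear with another group on that sulfonamide nitrogen, such as a plain phenyl ring, a pyrimidine ring without its methyl groups, or a longer alkyl chain. They also leave open whether the step would persist on a core carrying a methoxy group or a fluorine.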